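From carboxy to methylpiperazine at a solubility limit

This account rests on a few compounds, and the source may have more. Where it says the series, first, only, none or still open, it means among the compounds named here.

In a physicochemical assay for solubility, using the shake flask method, measured as kinetic solubility, with a stated time of 20 h, at pH 2 (on this read-out lower numbers stand for lower solubility and higher numbers for higher solubility), compound 1 `COc1ccc(Nc2cc3[nH]c(-c4cccc(C(F)(F)F)c4)nc3cn2)nc1` gives < 5000 nM as a limit. Compound 2 `N#Cc1ccc(Nc2cc3[nH]c(-c4cccc(C(F)(F)F)c4)nc3cn2)nc1` gives < 5000 nM as a limit too. Compound 3 `O=C(O)c1ccc(Nc2cc3[nH]c(-c4cccc(C(F)(F)F)c4)nc3cn2)nc1` also stands only at a limit, < 5000 nM and no number. Compound 4 `CN1CCN(c2ccc(Nc3cc4[nH]c(-c5cccc(C(F)(F)F)c5)nc4cn3)nc2)CC1` brings a new change: 4-methylpiperazin-1-yl in place of carboxy on an aromatic carbon with 4-methylpiperazin-1-yl in place of carboxy on an aromatic carbon. The step that the two limits leave unreadable from compound 1 to compound 3 and the step that the two limits leave unreadable from compound 2 to compound 3 touch the same place, yet neither has a readable size to carry over. An upward step an at least 2.0-fold higher number from compound 3 to compound 4 (0.30 log units; that floor lies within the scatter) is expected, though it rests on the structural change alone and is held loosely. In this assay the estimate for compound 4 is 10000 nM with an expected range from 2500 nM to 60000 nM around it.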

Compound 4, solubility: 190000 nM
The estimate for compound 4 lay 19-fold (1.28 log units) below the measured number; the measured number lies above the stated range.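

In this assay, the aromatic carbon two atoms from the ring nitrogen now shows a readable effect of substitution: 4-methylpiperazin-1-yl gives an at least 38-fold higher number from compound 3 to compound 4 (1.57 log units; beyond the scatter), an at least 38-fold higher number from compound 2 to compound 4 (1.57 log units; beyond the scatter) and an at least 38-fold higher number from compound 1 to compound 4 (1.57 log units; beyond the scatter). The steps among the methoxy, cyano and carboxy compounds cannot be read, and these three compounds share one limit: the limit of < 5000 nM in this assay, at which 3 of the 4 values shown sit.

On these data alone, how those three groups rank against one another stays open. Also open, as far as these compounds go, is whether the rise needs the whole 4-methylpiperazin-1-yl ring, which a morpholine or an open-chain dimethylamino group on the same carbon would test.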